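The compounds below may be only part of what the source reports. "The series", "measured", "known", "first", "only" and "open" are said of these compounds alone.

Working notes on the series.

All three measured compounds share one core and differ only at the saturated chain carbon bound to an aromatic nitrogen. Compound 1 `Cc1cc(C)c(Oc2cc(Nc3ccc(C#N)cc3)ncc2C(=O)NCc2cn(Cc3ccccc3F)nn2)c(C)c1` returns in an ADME assay on MT4 cells (Homo sapiens) for cytotoxicity, read by MTT assay, with a stated time of 5 days (on this read-out higher numbers stand for lower toxicity in this test and lower numbers for higher toxicity in this test), a limit of the assay rather than a number, > 222000 nM (the limit of > 222000 nM in this assay, at which 1 of the 3 values shown sits). Compound 2 `CCOC(=O)Cn1cc(CNC(=O)c2cnc(Nc3ccc(C#N)cc3)cc2Oc2c(C)cc(C)cc2C)nn1` gives 9530 nM in this assay, and compound 3 `COC(=O)Cn1cc(CNC(=O)c2cnc(Nc3ccc(C#N)cc3)cc2Oc2c(C)cc(C)cc2C)nn1` gives 13800 nM. Of the two numbers shown, compound 2 stands lowest, with compound 3 as its nearest neighbour at a 1.4-fold higher number from compound 2 to compound 3 (0.16 log units; within the scatter).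

Compound 4 `Cc1cc(C)c(Oc2cc(Nc3ccc(C#N)cc3)ncc2C(=O)NCc2cn(CCC#N)nn2)c(C)c1` differs from compound 2 by cyanomethyl in place of ethoxycarbonyl on a saturated chain carbon bound to an aromatic nitrogen. Within the data shown here, two measured steps bear on this place: an at least 23-fold lower number from compound 1 to compound 2 (1.36 log units; beyond the scatter) and an at least 16-fold lower number from compound 1 to compound 3 (1.20 log units; beyond the scatter) are both large, while a 1.4-fold higher number from compound 2 to compound 3 (0.16 log units; within the scatter) is small. Cyanomethyl is closer in size to the ethoxycarbonyl and methoxycarbonyl groups than to 2-fluorophenyl, so a move part of the way back towards compound 1 is expected, of uncertain size, with a wide range. Compound 4 is expected to give 25000 nM, between 6000 nM and 150000 nM. The step this estimate implies is a 2.6-fold higher number from compound 2 to compound 4 (0.42 log units; beyond the scatter), an expectation only.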

Compound 4, half-maximal cytotoxic concentration: 40200 nM
The estimate for compound 4 lay 1.6-fold (0.21 log units) below the measured number; the measured number falls inside the stated range.
By their numbers in this assay, from the lowest: compounds 2 and 3 (each within the scatter of the next); then compound 4. At a limit, above all of these: compound 1.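

In this assay, this place on a saturated chain carbon bound to an aromatic nitrogen now separates cyanomethyl from both ester groups: a 4.2-fold higher number from compound 2 to compound 4 (0.63 log units; beyond the scatter) and a 2.9-fold higher number from compound 3 to compound 4 (0.46 log units; beyond the scatter) are modest steps beyond the scatter, whereas ethoxycarbonyl and methoxycarbonyl lie within the scatter of each other. Cyanomethyl also remains apart from 2-fluorophenyl, with an at least 5.5-fold lower number from compound 1 to compound 4 (0.74 log units; beyond the scatter), so a group without a ring and without an ester can give a number that falls between those of the two earlier types of group. Compound 1 is a limit of the assay and not a number, so that last step is a bound only: the limit of > 222000 nM in this assay, at which 1 of the 4 values shown sits.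

As far as these compounds go, the true distance between cyanomethyl and 2-fluorophenyl remains open. From the compounds shown here alone, whether a carboxylic acid, an amine or a longer chain at this place would track cyanomethyl or the esters also remains open.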